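A few compounds are considered here, and "the series" means these few. Any claim that something is new, unique, unknown or untested is made for them only; others in the source may bear on it.

Of the compounds shown here, three that share one core have been measured in a physicochemical assay for lipophilicity, in phosphate buffer, measured as octanol-water partition, with a stated time of 24 h; on this read-out lower numbers stand for lower lipophilicity and higher numbers for higher lipophilicity. Compound 1 `S=C(N/N=C/c1ccc(Oc2ccc3ccccc3c2)cc1)Nc1ccc(Cl)cc1` gives 6.96 in this assay. Compound 2 `S=C(N/N=C/c1ccc(Oc2ccc(Br)cc2)cc1)Nc1ccc(Cl)cc1` gives 6.37 in this assay, and compound 3 `Fc1ccc(NC(=S)N/N=C/c2ccc(Oc3ccc(Br)cc3)cc2)cc1` gives 5.88 in this assay. Compound 2 therefore stands second highest of the three: compound 1 sits above it, with a number 0.59 log units lower from compound 1 to compound 2 (beyond the scatter), and compound 3 sits below it, with a number 0.49 log units lower from compound 2 to compound 3 (beyond the scatter). Compound 4 `S=C(N/N=C/c1ccc(Oc2ccc(Cl)cc2)cc1)Nc1ccc(Cl)cc1` has not yet been measured in this assay. It differs from compound 2 in one place: chloro in place of bromo on an aromatic carbon. Among the measured compounds shown here, no measured pair shows this exact swap. The nearest guide is the halogen exchange a number 0.49 log units lower from compound 2 to compound 3 (beyond the scatter), a modest fall when fluoro replaced chloro. A swap of chloro for bromo is expected to move the number less than that, landing near the edge of the usual scatter. The step from compound 2 to compound 4 is thus estimated at a number 0.22 log units lower from compound 2 to compound 4 (within the scatter). Compound 4 is accordingly expected to give about 6.15 in this assay, with a likely range from 5.8 to 6.5.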

Compound 4, partition coefficient: 6.2
Beside the measured number, compound 4's estimate is 0.05 log units below it; the range from low to high includes it.
By their numbers in this assay, from the lowest: compound 3; then compounds 4 and 2 (each within the scatter of the next); then compound 1.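

In this assay, exchanging bromo for chloro on the phenoxy group has no readable effect, with a number 0.17 log units lower from compound 2 to compound 4 (within the scatter), so the two halogens cannot be told apart at this position. Until now, bromo was the only halogen seen here, so the fall on leaving the naphthalen-2-yl group might have been particular to the 4-bromophenyl group; with 4-chlorophenyl in its place, the result is a number 0.76 log units lower from compound 1 to compound 4 (beyond the scatter), so a fall beyond the scatter holds for both halogen-bearing rings. Nothing available here offers an explanation for either step.

The compounds shown leave open how the number would respond at this position to a group of a different kind, such as an amine, a carboxylic acid or a methoxy group, in place of the halogen. On these data alone, it also remains open whether the exchange of bromo for chloro would stay this small with fluoro rather than chloro on the other side of the shared core, as in compound 3.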